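The compounds below may be only part of what the source reports. "The series", "measured", "known", "first", "only" and "open" are said of these compounds alone.

In a physicochemical assay for lipophilicity, measured as octanol-water partition, at pH 7.4 (a lower number here means a more polar compound, a higher number a more lipophilic compound), compound 1 `Cc1ccc(Cn2c(=O)[nH]c3c(N)nc(C(F)(F)F)cc32)cn1` gives 2.3 and compound 2 `Cc1cccc(Cn2c(=O)[nH]c3c(N)nc(C(F)(F)F)cc32)n1` gives 2.3. Compound 3 `Nc1nc(C(F)(F)F)cc2c1[nH]c(=O)n2Cc1ccc(C(F)(F)F)nc1` has no number, its entry reading "not determined" (no result reported), so the step under review starts from no measured value. Compound 4 `CN1CCN(c2ccc(Cn3c(=O)[nH]c4c(N)nc(C(F)(F)F)cc43)cn2)CC1` carries 4-methylpiperazin-1-yl in place of trifluoromethyl on an aromatic carbon. Within the data shown here, the one measured step shows no change at the digits printed from compound 1 to compound 2 (within the scatter), and it involves neither group, so it bears only weakly on this change. No size or direction of step from compound 3 can be stated, and the expectation rests on the level of compound 1 at 2.3, with wide margins. The estimate for compound 4 is 2.1, expected to fall in the range from 1.5 to 2.7.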

Compound 4, distribution coefficient: 1.8
For compound 4 the middle estimate is 0.30 log units above the measured one; the range from low to high includes it.
By their numbers in this assay, from the lowest: compound 4; then compounds 1 and 2 (each within the scatter of the next).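

In this assay, among these compounds, replacing methyl with 4-methylpiperazin-1-yl on the aromatic carbon next to the ring nitrogen gives a number 0.50 log units lower from compound 1 to compound 4 (beyond the scatter), the first step that lies beyond the scatter. The step from compound 3 to compound 4 cannot be read, as compound 3 has no number, so the exchange of trifluoromethyl for 4-methylpiperazin-1-yl stays unquantified. Nothing available accounts for the shift seen from compound 1.

Still open, on these data alone, is how morpholin-4-yl, a primary amine or a carboxylic acid at this place would compare. Also open, as far as these compounds go, is whether the step would have the same size with the 6-methylpyridin-2-yl arrangement of compound 2.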